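A few compounds are considered here, and "the series" means these few. Any claim that something is new, unique, unknown or untested is made for them only; others in the source may bear on it.

Measured so far:
Compound 1, `CCOC1=C(C(=O)c2ccccc2)C(c2ccc(Br)cc2)N(CCCn2ccnc2)C1=O`: 21900 nM
Compound 2, `NC1=C(C(=O)c2ccccc2)C(c2ccc(Br)cc2)N(CCCn2ccnc2)C1=O`: 149000 nM

In a functional assay on U2OS cells (Homo sapiens) for antiproliferative activity, read by MTT assay, with a stated time of 72 h (on this read-out higher numbers stand for weaker inhibition and lower numbers for stronger inhibition), compound 2 gives the higher of the two numbers, standing above compound 1 by a 6.8-fold higher number from compound 1 to compound 2 (0.83 log units; beyond the scatter). Compound 3, `Cc1ccc(NC2=C(C(=O)c3ccccc3)C(c3ccc(Br)cc3)N(CCCn3ccnc3)C2=O)cc1`, has not yet been measured in this assay. It differs from compound 2 by 4-methylphenyl in place of hydrogen on an amine nitrogen, so that the amino of compound 2 becomes a (4-methylphenyl)amino. Among the measured compounds shown here, only one measured step is known, the one from compound 1 to compound 2, and it concerns a different change, ethoxy to amino on the double-bonded ring carbon; no measured pair speaks to an aryl group entering on the amine nitrogen. Compound 3 is therefore expected to give a number in this assay that moves from compound 2 by a 3.0-fold lower number from compound 2 to compound 3 (0.47 log units; beyond the scatter), a modest fall carrying wide uncertainty. Compound 3 is estimated at 50000 nM in this assay, within a range from 15000 nM to 160000 nM.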

Compound 3, half-maximal inhibitory concentration: 24100 nM
Compound 3: middle estimate off by 2.1-fold (0.32 log units), on the high side; the range from low to high includes it.
By their numbers in this assay, from the lowest: compounds 1 and 3 (each within the scatter of the next); then compound 2.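

In this assay, the amine nitrogen on the double-bonded ring carbon tolerates substitution: 4-methylphenyl in place of hydrogen gives a 6.2-fold lower number from compound 2 to compound 3 (0.79 log units; beyond the scatter). The low activity of compound 2 is therefore not a fixed result of having nitrogen at this place, since the (4-methylphenyl)amino and the ethoxy cannot be told apart, with a 1.1-fold higher number from compound 1 to compound 3 (0.04 log units; within the scatter). Nothing available explains either step. The compounds shown leave open whether the fall in number from compound 2 needs the aromatic ring or its methyl, which a plain phenyl, a benzyl or a short alkyl chain on the same nitrogen would test. Also open, going by these compounds, is whether any other group here, such as a morpholine or a carboxylic acid, would give a number clearly lower than those of compound 1 and compound 3.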